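Shortening the chain to the hydroxycarbamoyl group in compound 1

A few compounds are considered here, and "the series" means these few. Any claim that something is new, unique, unknown or untested is made for them only; others in the source may bear on it.

Compound 1 `Nc1nc2cc(-c3nn(CCCCCCCCCC(=O)NO)c4ncnc(N)c34)ccc2o1` was tested in a functional assay on CNE-2 cells (Homo sapiens) for inhibition, read by MTT assay, with a stated time of 72 h (on this read-out lower numbers stand for stronger inhibition and higher numbers for weaker inhibition), and in this assay compound 1 gives 36800 nM. This is the highest of the three numbers, but the gap to compound 2 `Nc1ncnc2c1c(-c1cnc3[nH]ccc3c1)nn2CCCCCCC(=O)NO` is within the usual scatter: in this assay compound 2 gives 19500 nM. Compound 3 `Nc1ncnc2c1c(-c1cnc3[nH]ccc3c1)nn2CCCCCCCCCC(=O)NO` stands well apart; in this assay compound 3 gives 2200 nM, and the step of a 17-fold lower number from compound 1 to compound 3 (1.22 log units; beyond the scatter) is a change of the aromatic group on the shared core. The other step, an 8.9-fold lower number from compound 2 to compound 3 (0.95 log units; beyond the scatter), is a change of chain length alone.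

Compound 4 `Nc1nc2cc(-c3nn(CCC(=O)NO)c4ncnc(N)c34)ccc2o1` differs from compound 1 in the chain only: hydroxycarbamoyl in place of 7-(hydroxycarbamoyl)heptyl on a saturated chain carbon, two bonds along the chain from an aromatic nitrogen. The step from compound 2 to compound 3 bears on it directly, since there a longer chain gave a lower number; compound 4 carries the shortest chain of the four, so the change runs the other way and the number is expected to rise. Compound 1 already sits high, so the assay may report only a limit. For compound 4 the step is expected to be a 3.3-fold higher number from compound 1 to compound 4 (0.51 log units; beyond the scatter), and the estimate for compound 4 is 120000 nM, with a range from 40000 nM to 400000 nM.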

Compound 4, half-maximal inhibitory concentration: > 150000 nM
Compound 4 was reported as a limit; the forecaster's own chance of this, stated with the estimate: 40%; middle value at least 1.2-fold (0.09 log units) away from the limit.
By their numbers in this assay, from the lowest: compound 3; then compounds 2 and 1 (each within the scatter of the next). At a limit, above all of these: compound 4.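

In this assay compound 4 is reported only as a limit: the limit of > 150000 nM in this assay, at which 1 of the 4 values shown sits.

Replacing 7-(hydroxycarbamoyl)heptyl with hydroxycarbamoyl, on a saturated chain carbon, two bonds along the chain from an aromatic nitrogen, gives an at least 4.0-fold higher number from compound 1 to compound 4 (0.61 log units; beyond the scatter). This shows that chain length also matters with the aromatic group of compound 1, whereas the earlier chain comparison involved only the different aromatic group of compound 2 and compound 3. Alongside an 8.9-fold lower number from compound 2 to compound 3 (0.95 log units; beyond the scatter), the shorter chain carries the higher number in both pairs, and neither pair goes against this pattern.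

The compounds shown leave open how the number changes at intermediate chain lengths with the aromatic group of compound 1, and whether a longer chain than 7-(hydroxycarbamoyl)heptyl would lower it further. They also leave open whether a carboxylic acid or an amine at the chain end, in place of the hydroxycarbamoyl group, would preserve the number of compound 3, which gives 2200 nM.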